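Cytotoxicity Limits Hold Across Three Measured Compounds

A few compounds are considered here, and "the series" means these few. Any claim that something is new, unique, unknown or untested is made for them only; others in the source may bear on it.

Compound 1 `CC(C)CCn1c(Cn2c(=O)n(C3CC3)c3ccncc32)nc2nc(Cl)ccc21`: > 50000 nM
Compound 2 `COc1ccc2c(c1)cc(Cn1c(=O)n(C3CC3)c3ccncc31)n2CCCCO`: > 50000 nM
Compound 3 `COc1ccc(-n2c(=O)n(Cc3cc4cc(Cl)ccc4n3CCCC#N)c3cnccc32)cc1OC`: > 50000 nM

The three compounds were tested in an ADME assay on HeLa cells (Homo sapiens) for cytotoxicity, read by ATP content, with a stated time of 3 days; on this read-out higher numbers stand for lower toxicity in this test and lower numbers for higher toxicity in this test. Compound 3 gives > 50000 nM, which is a limit of the assay and not a number. For the measured compounds named here, the other two entries are limits as well, so all that is known is the limit of > 50000 nM in this assay, at which 3 of the 3 values shown sit; no step between measured compounds can be drawn, and compound 3 cannot be placed above or below the others.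

Compound 4 `N#CCCCn1c(Cn2c(=O)n(-c3ccncc3F)c3ccncc32)cc2cc(Cl)ccc21` has not yet been measured in this assay. It differs from compound 3 in one place: 3-fluoropyridin-4-yl in place of 3,4-dimethoxyphenyl on an aromatic nitrogen. Going by the values given here, since every measured compound sits at the limit, there is no measured step to lean on, and no change beyond the scatter is expected for this assay in either direction.

The step from compound 3 to compound 4 is expected to be a number no higher from compound 3 to compound 4 (the limit leaves the size open). Compound 4 is therefore estimated at 50000 nM, within a range from 20000 nM to 100000 nM, most likely reported again as a limit.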

Compound 4, half-maximal cytotoxic concentration: > 50000 nM
Compound 4 gave a limit, no number (the forecaster's own chance of this, stated with the estimate: 85%); the middle value sits exactly at the limit.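

In this assay the entries for compound 3 and compound 4 are both limits and not numbers, so no step between them can be read: the limit of > 50000 nM in this assay, at which 4 of the 4 values shown sit.

The compounds shown leave open where any true value lies, and whether 3-fluoropyridin-4-yl in place of 3,4-dimethoxyphenyl changes the read-out at all.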